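Quinoline ether tetrazoles: removing the propyl branch

The source may report more compounds than this note shows. Statements on the series, on what has been measured and on what is new or still open speak of the compounds shown alone.

Working notes on the series. Compound 1 `c1ccc2nc(COc3ccc(CC4CCCC4Cc4nnn[nH]4)cc3)ccc2c1` and compound 2 `CCCC(CCc1nnn[nH]1)Cc1cccc(OCc2ccc3ccccc3n2)c1` share the quinolinylmethoxy aryl core and an acidic tetrazole on a saturated chain. In an assay on membranes from lung (Cavia porcellus) for binding affinity to cysteinyl leukotriene receptor (Homo sapiens) (a higher number here means a weaker inhibitor, a lower number a stronger inhibitor), compound 2 gives 11 nM, the lower of the two numbers, and compound 1 gives 15 nM; the gap between the two falls within the usual scatter of this assay, so no order can be read from it. Compound 3 `c1cc(CCCCc2nnn[nH]2)cc(OCc2ccc3ccccc3n2)c1` has not been measured. It differs from compound 2 by hydrogen in place of propyl on a saturated chain carbon bound to two saturated chain carbons. Among the compounds with values here, no measured pair in this set shows the effect of removing a chain branch, so the expectation rests only on the two values above. The change is expected to cost some affinity, with a step of a 2.3-fold higher number from compound 2 to compound 3 (0.36 log units; beyond the scatter) from compound 2 to compound 3, though a result within the scatter cannot be excluded. Compound 3 is therefore estimated at 25 nM in this assay, with a range from 8 nM to 80 nM.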

Compound 3, inhibition constant: 20 nM
Estimate against measurement, compound 3: 1.3-fold (0.10 log units) above; the range from low to high includes it.
By their numbers in this assay, from the lowest: compounds 2, 1 and 3 (each within the scatter of the next).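

Within the data shown here, this pair gives the first direct reading at this position: in this assay, hydrogen in place of propyl on a saturated chain carbon bound to two saturated chain carbons gives a 1.8-fold higher number from compound 2 to compound 3 (0.26 log units; within the scatter). Removing the propyl branch therefore produces no change that can be told apart from repeat-measurement scatter, and this assay shows no need for the branch to retain affinity. No measurement available here bears on the reason for this result.

Going by these compounds, whether a longer chain such as hexyl, or a phenyl group, on the same carbon would move the number beyond the scatter remains open. Also open, on these data alone, is how a carboxylic acid in place of the tetrazole would read on the unbranched chain of compound 3.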